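Acetamido to acetoxy on a saturated ring carbon

A few compounds are considered here, and "the series" means these few. Any claim that something is new, unique, unknown or untested is made for them only; others in the source may bear on it.

In an ADME assay on Vero cells (Chlorocebus sabaeus) for cytotoxicity, read by MTT assay, with a stated time of 48 h (a higher number here means a weaker inhibitor, a lower number a stronger inhibitor), compound 1 `CC(=O)NC1CCC(CN2CCN(c3cc(=O)c4cc(C(F)(F)F)cc([N+](=O)[O-])c4s3)CC2)CC1` reaches only the limit > 64 ug/mL. Compound 2 `O=C(OC1CCC(CN2CCN(c3cc(=O)c4cc(C(F)(F)F)cc([N+](=O)[O-])c4s3)CC2)CC1)c1ccc(F)cc1` likewise gives in this assay the limit > 64 ug/mL. For the measured compounds named here, the single comparison at hand, a step that the two limits leave unreadable from compound 1 to compound 2, cannot be read, since (the limit of > 64 ug/mL in this assay, at which 2 of the 2 values shown sit). Compound 3 `CC(=O)OC1CCC(CN2CCN(c3cc(=O)c4cc(C(F)(F)F)cc([N+](=O)[O-])c4s3)CC2)CC1` differs from compound 1 by acetoxy in place of acetamido on a saturated ring carbon. Going by the values given here, no measured step speaks to this change, and two limits give no size to expect in this assay, in either direction. Compound 3 is therefore expected also to sit at the limit, estimated at 80 ug/mL between 45 ug/mL and 200 ug/mL, a step that the limit leaves unreadable from compound 1 to compound 3.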

Compound 3, half-maximal inhibitory concentration: > 64 ug/mL
Compound 3: no number, only a limit (the forecaster's own chance of this, stated with the estimate: 85%); the middle value lies beyond the limit too.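

For the compounds shown here, compound 1, compound 2 and compound 3 all reach only a limit in this assay, so no step among them can be read: the limit of > 64 ug/mL in this assay, at which 3 of the 3 values shown sit. The compounds shown leave open whether any group on that saturated ring carbon would give a number in this assay rather than a limit.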